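The source may hold more compounds than are shown below. What is called first, only, known or untested is meant among the compounds shown, and "the series" means these compounds.

Compound 1, with structure `CC[C@@H](Nc1c(C#N)c(-c2ccc(-c3cccc(OC)c3)cc2)nc2cnccc12)C(N)=O`, in a physicochemical assay for lipophilicity, read by HPLC, at pH 7.5 (on this read-out higher numbers stand for higher lipophilicity and lower numbers for lower lipophilicity), gives 2.7.
Compound 2, with structure `CC[C@@H](Nc1c(C#N)c(-c2ccc(-c3ccc(F)cc3)cc2)nc2cnccc12)C(N)=O`, in this assay gives 2.7.
Compound 3, with structure `CC[C@@H](Nc1c(C#N)c(-c2ccc(-c3ccccc3COC)cc2)nc2cnccc12)C(N)=O`, in this assay gives 2.6.

The three measured compounds share one core and differ only in the outer aromatic group. On the numbers shown, compound 3 has the lowest value, yet the step of a number 0.10 log units lower from compound 1 to compound 3 (within the scatter) and the step of a number 0.10 log units lower from compound 2 to compound 3 (within the scatter) both stay within the scatter, so all three sit within the scatter of one another, and no order among them can be claimed. Compound 4, with structure `CC[C@@H](Nc1c(C#N)c(-c2ccc(-c3ccccc3F)cc2)nc2cnccc12)C(N)=O`, has not yet been measured in this assay. It differs from compound 3 in one place: fluoro in place of methoxymethyl on an aromatic carbon.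

For the measured compounds named here, the step that bears most directly on this change is the one from compound 2 to compound 3, where a 2-(methoxymethyl)phenyl replaced a 4-fluorophenyl and the result was a number 0.10 log units lower from compound 2 to compound 3 (within the scatter). The steps of no change at the digits printed from compound 1 to compound 2 (within the scatter) and a number 0.10 log units lower from compound 1 to compound 3 (within the scatter) likewise stayed within the scatter. On that basis the step from compound 3 to compound 4 is expected to be a number 0.10 log units higher from compound 3 to compound 4 (within the scatter), that is, no shift beyond the scatter in either direction. Compound 4 is therefore estimated at 2.7, with a likely range from 2.4 to 3.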

Compound 4, distribution coefficient: 2.7
Compound 4: middle estimate and measured number agree at the digits printed; low and high end bracket the measured number.
By their numbers in this assay, from the lowest: compounds 3, 1, 2 and 4 (each within the scatter of the next).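

In this assay, fluoro in place of methoxymethyl on this aromatic carbon, ortho to a large group, gives a small step (a number 0.10 log units higher from compound 3 to compound 4 (within the scatter)), even though 1 heavy atom replaces 3 heavy atoms and the 1 hydrogen-bond acceptor of methoxymethyl is gone. The earlier compounds carried fluoro only as 4-fluorophenyl, and 2-fluorophenyl in its place also leaves the read-out within the scatter (no change at the digits printed from compound 2 to compound 4 (within the scatter)), as does 2-fluorophenyl in place of 3-methoxyphenyl (no change at the digits printed from compound 1 to compound 4 (within the scatter)), so all four outer groups shown fit one narrow band with no order among them. No measurement is available that would explain why these changes leave the number so little altered.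

The groups exchanged at this position, methoxymethyl and fluoro, carry no net charge, so the compounds shown leave open whether an amine or a carboxylic acid on the same aromatic carbon would stay in this band. They also leave open what a longer chain, such as methoxyethyl, or a second ring at this place would do to the read-out.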